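From 2-phenylethenyl to ethyl on a sulfonyl sulfur

The source may hold more compounds than are shown below. What is called first, only, known or untested is meant among the compounds shown, and "the series" means these compounds.

- Compound 1 `C=CS(=O)(=O)N1CCN(c2ncnc3sc(-c4ccc(C#N)cc4)cc23)CC1` gives 8050 nM as its value
- Compound 2 `C=CS(=O)(=O)N1CCN(c2ncnc3sc(-c4ccc(N5CCN(C)CC5)cc4)cc23)CC1` gives 7550 nM as its value
- Compound 3 `CN1CCN(c2ccc(-c3cc4c(N5CCN(S(=O)(=O)/C=C/c6ccccc6)CC5)ncnc4s3)cc2)CC1` gives 5900 nM as its value

These three values come from a functional assay on MDA-MB-231 cells (Homo sapiens) for antiproliferative activity, read by MTT assay, with a stated time of 48 h (on this read-out higher numbers stand for weaker inhibition and lower numbers for stronger inhibition), and lie within the scatter of one another. Compound 3 at 5900 nM therefore stands level with compound 1 and compound 2 and does not separate from them.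

Compound 4 `CCS(=O)(=O)N1CCN(c2ncnc3sc(-c4ccc(N5CCN(C)CC5)cc4)cc23)CC1` has not yet been measured. It carries ethyl in place of 2-phenylethenyl on a sulfonyl sulfur, and the difference from compound 3 counts as follows: ethyl in place of 2-phenylethenyl on a sulfonyl sulfur (the sulfur's other neighbour being a sulfonamide nitrogen in a ring).

For the measured compounds named here, the one measured step at that same sulfonyl sulfur is a 1.3-fold lower number from compound 2 to compound 3 (0.11 log units; within the scatter) and it brought in the 2-phenylethenyl that now leaves. The other measured step is a 1.1-fold lower number from compound 1 to compound 2 (0.03 log units; within the scatter) and it concerns an aromatic carbon, so it bears on this change only as a second small step. Going by the values given here, no compound with ethyl on the sulfonyl sulfur has a value yet, so the expectation rests on these small steps alone.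

The step expected in this assay is a 1.3-fold higher number from compound 3 to compound 4 (0.10 log units; within the scatter) and so none beyond the scatter. Compound 4 is estimated at 7500 nM with an expected range from 4000 nM to 15000 nM in this measurement.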

Compound 4, half-maximal inhibitory concentration: 7330 nM
Compound 4: the middle estimate sits 1.0-fold (0.01 log units) above what was measured, within the range that was stated.
By their numbers in this assay, from the lowest: compounds 3, 4, 2 and 1 (each within the scatter of the next).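

In this assay, the sulfonyl sulfur whose other neighbour is a sulfonamide nitrogen in a ring now has three groups compared on the same remainder, and both new steps, a 1.2-fold higher number from compound 3 to compound 4 (0.09 log units; within the scatter) and a 1.0-fold lower number from compound 2 to compound 4 (0.01 log units; within the scatter), lie within the scatter. Replacing 2-phenylethenyl, with its 8 heavy atoms and six-membered aromatic ring, by ethyl, with 2 heavy atoms, therefore does not separate compound 4 from compound 3, and the swap of vinyl for ethyl shows the same for the double bond outside aromatic rings when it is lost on its own, so neither that ring nor that double bond registers on this read-out among these compounds. Nothing available explains why these three groups read alike.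

Going by these compounds, how a longer chain ending in an amine, or a carboxylic acid, on the sulfonyl sulfur would read in this assay remains open. Also open, on these data alone, is whether ethyl at this place would read the same with cyano instead of 4-methylpiperazin-1-yl on the aromatic carbon, and whether any of these steps would hold in other cells.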